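Compound 4: a methoxyethyl amide replaces the pyrazolyl amine

This account rests on a few compounds, and the source may have more. Where it says the series, first, only, none or still open, it means among the compounds named here.

Of the compounds shown here, three sharing one core have been measured in a physicochemical assay for lipophilicity, using the shake flask method, in phosphate buffer, measured as octanol-water partition, with a stated time of 30 min, at pH 7.4; on this read-out lower numbers stand for lower lipophilicity and higher numbers for higher lipophilicity. Compound 1 `O=C(Nc1cnc(NCc2c(F)ccc3c2CCO3)n2cnnc12)c1ccccc1` gives 3, compound 2 `Fc1ccc2c(c1CNc1ncc(Nc3ccccc3)c3nncn13)CCO2` gives 3.3, and compound 3 `CN(c1ccn(C)n1)c1cnc(NCc2c(F)ccc3c2CCO3)n2cnnc12` gives 1.8. Compound 3 stands lowest of the three; its nearest neighbour is compound 1, and the drop a number 1.20 log units lower from compound 1 to compound 3 (beyond the scatter) is large, as is the drop a number 1.50 log units lower from compound 2 to compound 3 (beyond the scatter).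

Compound 4 `COCCC(=O)Nc1cnc(NCc2c(F)ccc3c2CCO3)n2cnnc12` has not yet been measured. It differs from compound 3 in one place: ((2-methoxyethyl)carbonyl)amino in place of methyl(1-methyl-1H-pyrazol-3-yl)amino on an aromatic carbon. Among the compounds with values here, the steps that bear on this are those leading into compound 3, since compound 1 also carries an amide at the same carbon and the move from it to compound 3 lowered the number by a number 1.20 log units lower from compound 1 to compound 3 (beyond the scatter). Reversing that step would point back toward the value of compound 1, but compound 4 carries a chain of four carbons and two oxygens in place of the phenyl ring of the benzamido group, and no measured step covers that exchange. Weighing the amide return against the loss of the ring, a small step is expected, a number 0.10 log units lower from compound 3 to compound 4 (within the scatter), likely within the scatter. Compound 4 is therefore estimated at 1.7, with a range from 1.1 to 2.3.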

Compound 4, distribution coefficient: 1.4
The estimate for compound 4 lay 0.30 log units above the measured number, and the stated range covers the measured number.
By their numbers in this assay, from the lowest: compound 4; then compound 3; then compounds 1 and 2 (each within the scatter of the next).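

Keeping the amide at this aromatic carbon does not keep the number near that of compound 1: with 2-methoxyethyl in place of phenyl on the carbonyl carbon, the change is a number 1.60 log units lower from compound 1 to compound 4 (beyond the scatter) in this assay, and the step from the anilino compound is similar at a number 1.90 log units lower from compound 2 to compound 4 (beyond the scatter). Within the data shown here, the group on the far side of the amide therefore matters at least as much here as the amide itself, and the earlier compounds, which all carried a ring in this substituent, could not show that. A substituent with no ring also goes past the methyl(1-methyl-1H-pyrazol-3-yl)amino group, with a number 0.40 log units lower from compound 3 to compound 4 (beyond the scatter) making compound 4 the lowest of the four, although nothing available gives a reason for these steps.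

As far as these compounds go, with only phenyl and 2-methoxyethyl on this carbonyl carbon, it remains open whether the step follows the loss of the ring or the oxygen in the chain, and a plain propyl chain on the same carbonyl would separate the two. From the compounds shown here alone, how an amine or a carboxylic acid at the end of the chain would read in this assay also remains open.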